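Swapping 4-fluorophenyl for 3-chlorophenyl on a shared core

A few compounds are considered here, and "the series" means these few. Any claim that something is new, unique, unknown or untested is made for them only; others in the source may bear on it.

Compound 1 `O=C(CN1CCN(C(=O)c2ccc(Cl)cc2)CC1)N1CCN(CCCc2c[nH]c3ccccc23)CC1` gives 98200 nM
Compound 2 `Cc1ccc(C(=O)N2CCN(CC(=O)N3CCN(CCCc4c[nH]c5ccccc45)CC3)CC2)cc1` gives 159000 nM
Compound 3 `O=C(CN1CCN(C(=O)c2ccc(F)cc2)CC1)N1CCN(CCCc2c[nH]c3ccccc23)CC1` gives 141000 nM

In an ADME assay on HEK293 cells (Homo sapiens) for cytotoxicity, read by MTT assay, with a stated time of 72 h (on this read-out lower numbers stand for stronger inhibition and higher numbers for weaker inhibition), these three compounds all lie within the scatter of one another, so compound 3 cannot be told apart from the other two on its number.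

Compound 4 `O=C(CN1CCN(C(=O)c2cccc(Cl)c2)CC1)N1CCN(CCCc2c[nH]c3ccccc23)CC1` differs from compound 3 by a single change 3-chlorophenyl in place of 4-fluorophenyl on a carbonyl carbon. The most relevant measured step is fluoro in place of chloro on an aromatic carbon (a 1.4-fold higher number from compound 1 to compound 3 (0.16 log units; within the scatter)). The two steps involving methyl on an aromatic carbon, (a 1.6-fold higher number from compound 1 to compound 2 (0.21 log units; within the scatter)) and (a 1.1-fold lower number from compound 2 to compound 3 (0.05 log units; within the scatter)), are of similar size, and all three stay within the scatter. Going by the values given here, no measured compound carries 3-chlorophenyl, so the data hold no direct step for that group. Compound 1 is the nearest measured match, as it also bears chloro, and its step to compound 3 was small (a 1.4-fold higher number from compound 1 to compound 3 (0.16 log units; within the scatter)). No change beyond the scatter is therefore expected in this assay, only an estimated 1.2-fold lower number from compound 3 to compound 4 (0.09 log units; within the scatter) (a slight drift towards compound 1 at most). For compound 4 the estimated value is 115000 nM (expected range 65000 nM to 200000 nM).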

Compound 4, half-maximal inhibitory concentration: 99100 nM
Beside the measured number, compound 4's estimate is 1.2-fold (0.06 log units) above it; the range from low to high includes it.
By their numbers in this assay, from the lowest: compounds 1, 4, 3 and 2 (each within the scatter of the next).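

In this assay, 3-chlorophenyl in place of 4-fluorophenyl on a carbonyl carbon gives a 1.4-fold lower number from compound 3 to compound 4 (0.15 log units; within the scatter), and 3-chlorophenyl in place of 4-methylphenyl gives a 1.6-fold lower number from compound 2 to compound 4 (0.21 log units; within the scatter), so neither swap can be told apart from the ordinary spread of repeat measurements. The new information comes from the pair that carries chlorine at two different ring positions: 3-chlorophenyl in place of 4-chlorophenyl gives a 1.0-fold higher number from compound 1 to compound 4 (0.00 log units; within the scatter), so changing where the chlorine sits on the phenyl ring leaves no readable difference here. All four aryl groups shown on this carbonyl carbon therefore lie within the scatter of one another, though no further measurement is available to explain this.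

The compounds shown leave open whether an amine or a carboxylic acid on the phenyl ring would move the number in this assay beyond the scatter, since the only ring substituents here are chloro, fluoro and methyl. Going by these compounds, it also remains open whether a longer chain in place of the phenyl ring on this carbonyl carbon would change the number.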